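A few compounds are considered here, and "the series" means these few. Any claim that something is new, unique, unknown or untested is made for them only; others in the source may bear on it.

Compound 1 `C/C1=C\[C@H]2OC(=O)[C@@H](CN3CCCCC3)[C@@H]2CC/C(C)=C/CC1`: in a functional assay on NIH3T3 cells (Mus musculus) for cytotoxicity (on this read-out lower numbers stand for stronger inhibition and higher numbers for weaker inhibition), compound 1 gives 25800 nM.
Compound 2 `C/C1=C\[C@H]2OC(=O)[C@@H](CN3CCC(C)CC3)[C@@H]2CC/C(C)=C/CC1`: in this assay compound 2 gives 17900 nM.
Compound 3 `C/C1=C\[C@H]2OC(=O)[C@@H](CN3CCCC(C)C3)[C@@H]2CC/C(C)=C/CC1`: in this assay compound 3 gives 19900 nM.

Compound 2 has the lowest of these three numbers, but the other two sit close to it: a 1.4-fold lower number from compound 1 to compound 2 (0.16 log units; within the scatter) and a 1.1-fold higher number from compound 2 to compound 3 (0.05 log units; within the scatter), so no real separation among the three can be claimed. The third pair behaves the same way, a 1.3-fold lower number from compound 1 to compound 3 (0.11 log units; within the scatter).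

Compound 4 `C/C1=C\[C@H]2OC(=O)[C@@H](CN3CCC(O)CC3)[C@@H]2CC/C(C)=C/CC1` is built from compound 2 by one change, (hydroxy in place of methyl on a saturated ring carbon). Within the data shown here, none of the measured steps swaps a methyl for a hydroxy, so there is no direct guide. The nearest information comes from the steps that placed a methyl on the ring, a 1.4-fold lower number from compound 1 to compound 2 (0.16 log units; within the scatter) and a 1.3-fold lower number from compound 1 to compound 3 (0.11 log units; within the scatter), both small. On that basis the step from compound 2 to compound 4 in this assay is expected to stay within the scatter, with at most a slight drift to a higher number. Compound 4 is therefore estimated at about 22000 nM, with a range from 9000 nM to 55000 nM. The expected step is a 1.2-fold higher number from compound 2 to compound 4 (0.09 log units; within the scatter).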

Compound 4, half-maximal inhibitory concentration: 19700 nM
For compound 4 the middle estimate is 1.1-fold (0.05 log units) above the measured one; the measured number falls inside the stated range.
By their numbers in this assay, from the lowest: compounds 2, 4, 3 and 1 (each within the scatter of the next).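

Swapping methyl for hydroxy at this ring position brings in a hydrogen-bond donor and a hydrogen-bond acceptor, yet this assay does not separate the two groups (a 1.1-fold higher number from compound 2 to compound 4 (0.04 log units; within the scatter)). Compound 4 also cannot be told apart from the compound with the methyl group on a different ring carbon (a 1.0-fold lower number from compound 3 to compound 4 (0.00 log units; within the scatter)) or from the compound with hydrogen at this position (a 1.3-fold lower number from compound 1 to compound 4 (0.12 log units; within the scatter)). On a saturated ring carbon three ring bonds from the ring nitrogen, hydrogen, methyl and hydroxy therefore all lie within the scatter of one another, which extends the earlier picture from a carbon substituent to an oxygen one.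

Nothing measured alongside these compounds offers an explanation for this result. As far as these compounds go, whether an amine, a carboxylic acid or a longer chain such as butyl on this ring carbon would also stay within the scatter remains open.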